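Phenyl for Methyl on a Piperazine Nitrogen

A few compounds are considered here, and "the series" means these few. Any claim that something is new, unique, unknown or untested is made for them only; others in the source may bear on it.

In a functional assay on MCF7 cells (Homo sapiens) for antiproliferative activity, read by sulforhodamine B assay, with a stated time of 48 h (a lower number here means a stronger inhibitor of growth, a higher number a weaker inhibitor of growth), compound 2 `CN1CCN(CCCNc2ccnc3cc(Cl)ccc23)CC1` gives 17100 nM, and compound 1 `Clc1ccc2c(NCCCN3CCCC3)ccnc2c1` gives 21500 nM, the two numbers lying within the scatter of each other, as the step of a 1.3-fold lower number from compound 1 to compound 2 (0.10 log units; within the scatter) shows. Compound 3 `Clc1ccc2c(NCCCN3CCN(c4ccccc4)CC3)ccnc2c1` differs from compound 2 by phenyl in place of methyl on an amine nitrogen in a ring. Within the data shown here, no measured step bears directly on this change; the one step known, an exchange of the amine ring itself, stayed within the scatter, so only a small step in this assay is expected, with the direction uncertain. Compound 3 is therefore expected to give 12000 nM, within a range of 4000 nM to 36000 nM, an expected step of a 1.4-fold lower number from compound 2 to compound 3 (0.15 log units; within the scatter).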

Compound 3, concentration for 50% growth inhibition: 12800 nM
The estimate for compound 3 lay 1.1-fold (0.03 log units) below the measured number; low and high end bracket the measured number.
By their numbers in this assay, from the lowest: compounds 3, 2 and 1 (each within the scatter of the next).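

In this assay, phenyl in place of methyl on the amine nitrogen adds a six-membered aromatic ring of carbon only, yet the number stays within the scatter (a 1.3-fold lower number from compound 2 to compound 3 (0.13 log units; within the scatter)). The earlier step exchanged the amine ring itself, whereas this one shows that a group of six heavy atoms on this nitrogen also leaves the number within the scatter. No measured evidence bears on this result. Going by these compounds, whether a benzyl or acetyl group on this nitrogen, or a longer chain to the amine ring, would produce a step beyond the scatter remains open.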